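This account rests on a few compounds, and the source may have more. Where it says the series, first, only, none or still open, it means among the compounds named here.

Measured so far:
compound 1, `CS(=O)(=O)N1CCN(CC(O)CN2CCC(NC(=O)c3cccc4[nH]cnc34)CC2)CC1`, 63100 nM
compound 2, `CC(C)c1nc2c(C(=O)NCC3CCN(CCN4CCN(S(C)(=O)=O)CC4)CC3)cccc2[nH]1`, 100000 nM

The two compounds were tested in an assay on isolated protein for binding affinity to 5-hydroxytryptamine receptor 3A (Homo sapiens); a higher number here means a weaker inhibitor, a lower number a stronger inhibitor. In this assay compound 1 gives 63100 nM, and compound 2 gives 100000 nM. Compound 2 thus has the higher of the two numbers, but its gap to compound 1 lies within the usual scatter of this assay, so the two values cannot be ranked against each other; both sit at the weak end of what this assay resolves.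

Compound 3, `CC(=O)N(C)CC(O)CN1CCC(CNC(=O)c2cccc3[nH]c(C(C)C)nc23)CC1`, has not been measured. It differs from compound 2 in one place: 2-(acetyl(methyl)amino)-1-hydroxyethyl in place of (4-(methylsulfonyl)piperazin-1-yl)methyl on a saturated chain carbon bound to an amine nitrogen in a ring. Among the measured compounds shown here, no step between measured compounds that changes this part of the molecule is available, so the size of the step can only be guessed from the two values shown. Because compound 2 gives 100000 nM and compound 1 gives 63100 nM with the shared core in both, a change at this chain position is expected to move the number little beyond the scatter in either direction. The estimated step from compound 2 to compound 3 is a 1.3-fold lower number from compound 2 to compound 3 (0.10 log units; within the scatter). For compound 3 the expected value in this assay is 80000 nM, within a range from 20000 nM to 300000 nM.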

Compound 3, inhibition constant: 63100 nM
Beside the measured number, compound 3's estimate is 1.3-fold (0.10 log units) above it; the measured number falls inside the stated range.
By their numbers in this assay, from the lowest: compounds 1, 3 and 2 (each within the scatter of the next).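

In this assay, among the compounds shown here, putting 2-(acetyl(methyl)amino)-1-hydroxyethyl in place of (4-(methylsulfonyl)piperazin-1-yl)methyl on a saturated chain carbon bound to an amine nitrogen in a ring gives a 1.6-fold lower number from compound 2 to compound 3 (0.20 log units; within the scatter), the first step that can be read at this place. The exchange is not a small one on paper: the group of 11 heavy atoms, with its six-membered non-aromatic ring and its sulfur, leaves, and an open group of 8 heavy atoms with 1 hydrogen-bond donor enters, yet the two compounds cannot be told apart in this read-out. Nothing at hand accounts for this outcome.

All of these values lie at the weak end of what the assay resolves, so a step within the scatter cannot show whether this place matters when the rest of the molecule binds more tightly. On these data alone, it remains open whether a different group here, such as a primary amine, a carboxylic acid or a longer alkyl chain, would move the number beyond the scatter.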